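This account rests on a few compounds, and the source may have more. Where it says the series, first, only, none or still open, it means among the compounds named here.

Measured so far in an assay on HeLa cells for displacement of a labelled ligand from 5-hydroxytryptamine receptor 6 (Homo sapiens), with a stated time of 2 h; on this read-out lower numbers stand for stronger inhibition and higher numbers for weaker inhibition:
compound 1, `CN1CCC(n2cc(S(=O)(=O)c3cccc4ccccc34)c3ccccc32)C1`; compound 1 gives 6 nM
compound 2, `O=S(=O)(c1cccc(F)c1)c1cn(C2CCCNC2)c2ccccc12`; compound 2 gives 6 nM
compound 3, `O=S(=O)(c1cccc2ccccc12)c1cn(C2CCCNC2)c2ccccc12`; compound 3 gives 21 nM

Compound 3 stands at the highest number of the three in this assay; compound 1 and compound 2 both sit below it by the same margin, and each of those gaps is beyond the scatter.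

The next compound is compound 4, `CN1CCCC(n2cc(S(=O)(=O)c3cccc4ccccc34)c3ccccc32)C1`. Relative to compound 3 the change is methyl in place of hydrogen on an amine nitrogen in a ring. Among the compounds with values here, only one measured step touches this part of the molecule: a 3.5-fold higher number from compound 1 to compound 3 (0.54 log units; beyond the scatter). That step alters the ring size and the methyl at once, so the two changes cannot be separated from one another. Compound 2 carries the same unmethylated ring as compound 3 but differs elsewhere in the molecule, and compound 2 gives 6 nM, which does not speak to the methyl. Because a 3.5-fold higher number from compound 1 to compound 3 (0.54 log units; beyond the scatter) places the methylated amine at the lower number, a modest fall in number on methylation is expected; the estimated step is a 2.1-fold lower number from compound 3 to compound 4 (0.32 log units; beyond the scatter). Compound 4 is therefore expected to give 10 nM, within a range from 4 nM to 30 nM.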

Compound 4, inhibition constant: 7.1 nM
The estimate for compound 4 lay 1.4-fold (0.15 log units) above the measured number; the measured number falls inside the stated range.
By their numbers in this assay, from the lowest: compounds 1, 2 and 4 (each within the scatter of the next); then compound 3.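

In this assay, methyl in place of hydrogen on the amine nitrogen of the piperidin-3-yl ring can now be read on its own (a 3.0-fold lower number from compound 3 to compound 4 (0.47 log units; beyond the scatter)), a change of a single heavy atom that moves the number beyond the scatter. The earlier step (a 3.5-fold higher number from compound 1 to compound 3 (0.54 log units; beyond the scatter)) changed ring size and methyl together, and the new comparison with the methyl held in place separates them: 1-methylpiperidin-3-yl in place of 1-methylpyrrolidin-3-yl leaves the number within the scatter (a 1.2-fold higher number from compound 1 to compound 4 (0.07 log units; within the scatter)). Among compounds 1, 3 and 4, the gap therefore follows the methyl on the ring nitrogen and not the ring size, and no measurement at hand bears on what lies behind this.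

From the compounds shown here alone, whether the methyl step holds with the fluorine-bearing aryl group on the sulfonyl of compound 2 stays open, as this step is read only with the naphthalene-bearing sulfonyl group of compounds 3 and 4. Also open, going by these compounds, is how the number responds to other groups on the same amine nitrogen, such as an ethyl, a 2-hydroxyethyl chain or an acetyl.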